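Replacing the 2,4-difluorophenyl group of compound 1

The source may hold more compounds than are shown below. What is called first, only, known or untested is meant among the compounds shown, and "the series" means these compounds.

Compound 1 `O=C(Nc1cc(F)c(F)c(F)c1)N1Cc2c(-c3ccc(F)cc3F)cnn2CC1C1CC1`: 32100 nM
Compound 2 `O=C1CC(c2cnc(C(F)(F)F)s2)CN1c1cnn2c1CN(C(=O)Nc1cc(F)c(F)c(F)c1)C(C1CC1)C2`: 38500 nM

In a toxicity assay on HepG2 2.2.15 cells (Homo sapiens) for cytotoxicity, read by CellTiter-Glo (a lower number here means that less compound is tolerated, a higher number that more compound is tolerated), compound 1 stands level with compound 2: their two numbers lie within the usual scatter of each other, so neither can be ranked above the other. Compound 3 `O=C1NC(c2ccccc2)CN1c1cnn2c1CN(C(=O)Nc1cc(F)c(F)c(F)c1)C(C1CC1)C2` has not yet been measured. It keeps the core of compound 1 but carries 2-oxo-4-phenylimidazolidin-1-yl in place of 2,4-difluorophenyl on an aromatic carbon. Going by the values given here, no step between measured compounds isolates this change. Compound 2 also lacks the 2,4-difluorophenyl group and gives 38500 nM, so no step beyond the scatter is expected in this assay, in either direction. The expected step is a 1.2-fold higher number from compound 1 to compound 3 (0.07 log units; within the scatter). For compound 3 the estimated value is 38000 nM, with an expected range from 16000 nM to 90000 nM.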

Compound 3, half-maximal cytotoxic concentration: 38500 nM
Estimate against measurement, compound 3: 1.0-fold (0.01 log units) below; measured number inside the range.
By their numbers in this assay, from the lowest: compounds 1, 2 and 3 (each within the scatter of the next).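

Putting 2-oxo-4-phenylimidazolidin-1-yl in place of 2,4-difluorophenyl on an aromatic carbon gives, in this assay, a 1.2-fold higher number from compound 1 to compound 3 (0.08 log units; within the scatter) and so leaves compound 1 and compound 3 unranked. The group that enters has more heavy atoms than the one that leaves, and it adds a five-membered non-aromatic ring with 2 hetero atoms and a hydrogen-bond donor and acceptor, yet the numbers remain level within the scatter. Nothing available here accounts for this level result.

Whether an amine, a carboxylic acid or a plain methyl group at this place would also stay level remains open, since each group shown here carries an aromatic ring. Also open is how compound 3 behaves in any assay other than this assay, the only one shown.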